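Shifting Fluorine Around the Sulfonyl Aryl Group

The source may hold more compounds than are shown below. What is called first, only, known or untested is meant among the compounds shown, and "the series" means these compounds.

Of the compounds shown here, two sharing one core have been measured in an assay on isolated protein for displacement of a labelled ligand from metabotropic glutamate receptor 5 (Homo sapiens), with a stated time of 60 min, tested at 1 uM; a higher number here means more inhibition at the concentration tested (going by the name of the read-out), a lower number less inhibition. Compound 1 `CC1CCN(c2c(S(=O)(=O)c3cc(F)cc(F)c3)cnc3cc(Cl)ccc23)CC1` gives 94% in this assay. Compound 2 `CC1CCN(c2c(S(=O)(=O)c3ccc(F)cc3)cnc3cc(F)ccc23)CC1` gives 74.5% in this assay, the lower of the two numbers, standing below compound 1 by a gap that lies beyond the scatter. Compound 1 and compound 2 differ in two places at once, so the two values alone do not show which change carries the gap.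

Compound 3 `CC1CCN(c2c(S(=O)(=O)c3cc(F)cc(F)c3)cnc3cc(F)ccc23)CC1` has not yet been measured. It differs from compound 2 in one place: 3,5-difluorophenyl in place of 4-fluorophenyl on a sulfonyl sulfur. Compound 3 thus carries the same group on the sulfonyl sulfur as compound 1, while keeping the rest of compound 2 unchanged.

Because compound 1 shows 94% with that same 3,5-difluorophenyl group, the step expected here is an increase, of moderate size, probably edging past the scatter: a number 10.5 percentage points higher from compound 2 to compound 3 (beyond the scatter). Compound 3 is therefore estimated to reach 85% in this assay, with a plausible range from 68% to 97%.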

Compound 3, a percentage reported as inhibition, at one concentration (the size of the read-out at that concentration, not a potency): 77%
Estimate against measurement, compound 3: 8 percentage points above, and the stated range covers the measured number.
By their numbers in this assay, from the lowest: compounds 2 and 3 (each within the scatter of the next); then compound 1.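

In this assay, exchanging 4-fluorophenyl for 3,5-difluorophenyl on a sulfonyl sulfur gives a number 2.5 percentage points higher from compound 2 to compound 3 (within the scatter) and leaves the two aryl groups not told apart on this background, a reading the earlier pair, with its two simultaneous differences, could not give. The other single change now readable, fluoro in place of chloro on an aromatic carbon, gives a number 17 percentage points lower from compound 1 to compound 3 (beyond the scatter) and is the only one of the two steps that lies beyond the scatter, which points to the halogen on the shared core, not the sulfonyl aryl group, as the place that matters among these compounds. Nothing in the data shown explains why one exchange registers and the other does not.

On these data alone, it remains open whether chloro on that aromatic carbon would show a comparable step when paired with 4-fluorophenyl, so the halogen step rests on the 3,5-difluorophenyl background alone. As far as these compounds go, how a bromo, a methoxy or a nitrile on that same carbon would read also stays open, and these single-concentration percentages give no potency for any of the compounds.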